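A Fluoro Group Removed at the Assay Limit

A few compounds are considered here, and "the series" means these few. Any claim that something is new, unique, unknown or untested is made for them only; others in the source may bear on it.

Compound 1 (`Nc1nc(N)c(CCCN(Cc2ccc(NC(CCC(=O)O)C(=O)O)cc2)c2cc(F)c(F)cc2[N+](=O)[O-])c(O)n1`), compound 2 (`Nc1nc(N)c(CCCN(Cc2ccc(NC(CCC(=O)O)C(=O)O)cc2)c2ccc([N+](=O)[O-])c(F)c2F)c(O)n1`) and compound 3 (`Nc1nc(N)c(CCCN(Cc2ccc(NC(CCC(=O)O)C(=O)O)cc2)c2cc(F)cc(F)c2[N+](=O)[O-])c(O)n1`) share one core and differ only in the difluoronitrophenyl group on the amine nitrogen. In a functional assay on CCRF-CEM cells (Homo sapiens) for cytotoxicity, in the absence of a further agent (a lower number here means a stronger inhibitor, a higher number a weaker inhibitor), compound 1 gives > 100000 nM as a limit of the assay. Compound 2 gives > 100000 nM as a limit too. Compound 3 gives > 100000 nM as a limit as well, so it has no number of its own. Compound 3 therefore stands level with the other two (the limit of > 100000 nM in this assay, at which 3 of the 3 values shown sit).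

Compound 4 (`Nc1nc(N)c(CCCN(Cc2ccc(NC(CCC(=O)O)C(=O)O)cc2)c2cc(F)ccc2[N+](=O)[O-])c(O)n1`) differs from compound 3 by one change (hydrogen in place of fluoro on an aromatic carbon), hydrogen in place of fluoro on an aromatic carbon, ortho to a nitro group, which turns 3,5-difluoro-2-nitrophenyl into 5-fluoro-2-nitrophenyl. The measured steps that bear on this are a step that the two limits leave unreadable from compound 1 to compound 3 and a step that the two limits leave unreadable from compound 2 to compound 3 along with a step that the two limits leave unreadable from compound 1 to compound 2 on the same phenyl group. None of them offers a size or a direction. No readable step is therefore expected in this assay in either direction. The estimate means a number no higher from compound 3 to compound 4 (the limit leaves the size open) as an expected step of no readable size. Compound 4 is estimated at 100000 nM with an expected range from 30000 nM to 300000 nM and is most likely to be reported as a limit again.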

Compound 4, half-maximal inhibitory concentration: > 100000 nM
Compound 4: a limit, no number; the forecaster's own chance of this, stated with the estimate: 85%; the middle value sits exactly at the limit.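

In this assay compound 4 gives > 100000 nM as a limit of the assay. No step among compound 1, compound 2, compound 3 and compound 4 can therefore be read: the limit of > 100000 nM in this assay, at which 4 of the 4 values shown sit.

From the compounds shown here alone, whether the fluoro groups on the phenyl group shift the value in this assay in either direction, and by how much, stays open.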